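Swapping a hydroxyphenyl for a fluorophenyl: cytotoxicity outlook

A few compounds are considered here, and "the series" means these few. Any claim that something is new, unique, unknown or untested is made for them only; others in the source may bear on it.

Compound 1 `O=c1cc(CNCc2ccccc2I)oc2ccc(O)c(O)c12` and compound 2 `O=c1cc(CNCc2cccc(O)c2)oc2ccc(O)c(O)c12` share a core and differ only in the aryl group on the chain carbon bound to the amine nitrogen. In an ADME assay on Huh-7 cells (Homo sapiens) for cytotoxicity (on this read-out lower numbers stand for higher toxicity in this test and higher numbers for lower toxicity in this test), compound 1 gives 87300 nM. In this assay compound 2 reaches only a limit of the assay, > 100000 nM, so for compound 2 only a range is known, as shown by the limit of > 100000 nM in this assay, at which 1 of the 2 values shown sits. The measured step is an at least 1.1-fold higher number from compound 1 to compound 2 (0.05 log units; that floor lies within the scatter). Compound 3 `O=c1cc(CNCc2ccc(F)cc2)oc2ccc(O)c(O)c12` is not yet measured; it differs from compound 2 by 4-fluorophenyl in place of 3-hydroxyphenyl on a saturated chain carbon bound to an amine nitrogen. Within the data shown here, the one measured step bears on it only loosely, as it touched the same position and stayed within the scatter. The step in this assay from compound 2 to compound 3 is therefore expected to be small, an at least 1.1-fold lower number from compound 2 to compound 3 (0.04 log units; that floor lies within the scatter), with no direction beyond the scatter. Compound 3 is estimated at 90000 nM, within a range from 40000 nM to 200000 nM.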

Compound 3, half-maximal cytotoxic concentration: > 100000 nM
Compound 3: no number, only a limit; the forecaster's own chance of this, stated with the estimate: 45%; at least 1.1-fold (0.04 log units) between middle value and limit.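

In this assay, compound 3 joins compound 2 at a limit of the assay rather than at a number: the limit of > 100000 nM in this assay, at which 2 of the 3 values shown sit. The step between these two limits therefore cannot be read, but the result does show that the hydroxyl group of compound 2 is not needed to reach this limit, as a 4-fluorophenyl group gets there too. Replacing the 2-iodophenyl group gives an at least 1.1-fold higher number from compound 1 to compound 3 (0.05 log units; that floor lies within the scatter), so with that floor inside the scatter, no real change is shown at this position.

From the compounds shown here alone, how compound 2 and compound 3 compare with each other remains open, since neither has a number. Also open, going by these compounds, is whether a carboxylic acid on the aryl ring, or a longer chain leading to it, would give a measurable value in this assay.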